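This account rests on a few compounds, and the source may have more. Where it says the series, first, only, none or still open, it means among the compounds named here.

Working notes on the series. Compound 1, `CCC1=C(O)c2c(oc(-c3ccccc3)cc2=O)C(CC)(CC)C1=O`, and compound 2, `CCC1=C(O)c2c(oc(-c3ccc(C)cc3)cc2=O)C(CC)(CC)C1=O`, share one core and differ only at the aryl substituent. In a functional assay on KB cells (Homo sapiens) for antiproliferative activity, read by sulforhodamine B assay, with a stated time of 3 days (on this read-out higher numbers stand for an effect only at larger amounts of compound and lower numbers for an effect already at smaller amounts), compound 1 is reported only as a limit, > 236 uM, which is the limit of > 236 uM in this assay, at which 1 of the 2 values shown sits. In this assay, going by the values given here, compound 2 gives 39.2 uM, the only number in the set. Among the compounds with values here, the step of an at least 6.0-fold lower number from compound 1 to compound 2 (0.77 log units; beyond the scatter) is the single measured step, with methyl in place of hydrogen on an aromatic carbon.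

Compound 3, `CCC1=C(O)c2c(oc(-c3ccc(C)c(F)c3)cc2=O)C(CC)(CC)C1=O`, carries the change (fluoro in place of hydrogen on an aromatic carbon). Within the data shown here, no measured step touches fluoro in place of hydrogen; the step of an at least 6.0-fold lower number from compound 1 to compound 2 (0.77 log units; beyond the scatter) concerns a methyl and gives no direct guide. The expectation for the step from compound 2 is therefore none beyond the scatter, a 1.1-fold lower number from compound 2 to compound 3 (0.05 log units; within the scatter). For compound 3 the estimate in this assay is 35 uM, expected between 10 uM and 120 uM.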

Compound 3, concentration for half-maximal effect: 28.1 uM
The estimate for compound 3 lay 1.2-fold (0.10 log units) above the measured number, and the stated range covers the measured number.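

Fluoro on the aromatic carbon ortho to a methyl group leaves the read-out in this assay within the scatter, with a 1.4-fold lower number from compound 2 to compound 3 (0.14 log units; within the scatter), so this position accepts the change without a measurable shift. With 3-fluoro-4-methylphenyl in place of phenyl, the series shows an at least 8.3-fold lower number from compound 1 to compound 3 (0.92 log units; beyond the scatter), which lies beyond the scatter, so the separation from the phenyl compound persists with fluoro present. Compound 1 remains a limit and not a number, so this step is only a bound: the limit of > 236 uM in this assay, at which 1 of the 3 values shown sits.

Open, on these data alone, is whether the methyl group of the 4-methylphenyl ring can give way to a longer chain such as propyl, or to an amine or a carboxylic acid. Also open, as far as these compounds go, is whether fluoro on the phenyl ring of compound 1, without the methyl group, gives a number in this assay.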